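Aryl ether variation in a thromboxane synthase series

A few compounds are considered here, and "the series" means these few. Any claim that something is new, unique, unknown or untested is made for them only; others in the source may bear on it.

Of the compounds shown here, two have been measured in an assay for inhibition of Thromboxane-A synthase (Homo sapiens), using microsomes; a higher number here means a weaker inhibitor, a lower number a stronger inhibitor. Compound 1 `O=C(O)CC/C=C\CC1COC(c2cccnc2)OC1c1cccnc1` gives 220 nM. Compound 2 `COc1ccc(OC(C)(C)C2OCC(C/C=C\CCC(=O)O)C(c3cccnc3)O2)cc1` gives 41 nM in this assay. Compound 2 therefore stands at the lower of the two numbers, and its gap to compound 1 lies beyond the scatter. The two compounds differ in more than one place, so nothing beyond what the two values show is read from the pair.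

Compound 3 `CC(C)(Oc1ccccc1[N+](=O)[O-])C1OCC(C/C=C\CCC(=O)O)C(c2cccnc2)O1` is the next compound and has not been measured. Relative to compound 2 the change is 2-nitrophenyl in place of 4-methoxyphenyl on an oxygen on a saturated carbon. The shared core of compound 2 is kept unchanged. Among the measured compounds shown here, no measured pair isolates an exchange of this kind, so there is no step to lean on, and the expectation rests on the value of compound 2 alone.

The step of a 1.5-fold higher number from compound 2 to compound 3 (0.17 log units; within the scatter) is expected to be small, a slight weakening that stays within the scatter. Compound 3 is accordingly estimated at 60 nM in this assay, with a range from 20 nM to 200 nM.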

Compound 3, half-maximal inhibitory concentration: < 10 nM
Compound 3: a limit, no number (the forecaster's own chance of this, stated with the estimate: 3%); at least 6.0-fold (0.77 log units) between middle value and limit.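

In this assay, among the compounds shown here, 2-nitrophenyl in place of 4-methoxyphenyl on an oxygen on a saturated carbon gives an at least 4.1-fold lower number from compound 2 to compound 3 (0.61 log units; beyond the scatter), the only step so far that isolates a change in one place. This shows that the aryl group at this position is not a silent part of the structure: this exchange alone, with the shared core kept, moves the number beyond the scatter, towards a stronger inhibitor. The full size of the step cannot be stated because compound 3 rests on a limit of the assay, not a number: the limit of < 10 nM in this assay, at which 1 of the 3 values shown sits.

The compounds shown do not separate the contribution of the nitro group from that of its place on the ring or from the loss of the methoxy group; 4-nitrophenyl, 2-methoxyphenyl and unsubstituted phenyl on the same oxygen would make that separation. Also open, from the compounds shown here alone, is whether the gain belongs to the nitro group specifically or would carry over to a 2-cyanophenyl or 2-aminophenyl group at this position.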